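Swapping an amino link for an ether in compound 4

The source may report more compounds than this note shows. Statements on the series, on what has been measured and on what is new or still open speak of the compounds shown alone.

Compound 1 `CN(C)CCCNc1ccc(S(=O)(=O)NC(=O)c2ccc(N3CCN(CC4=C(c5ccc(C(F)(F)F)cc5)CC(C)(C)CC4)CC3)cc2Oc2cnc3[nH]ccc3c2)cc1[N+](=O)[O-]`: 3.9 nM
Compound 2 `CC1(C)CCC(CN2CCN(c3ccc(C(=O)NS(=O)(=O)c4ccc(NCC5CCOC5)c([N+](=O)[O-])c4)c(Oc4cnc5[nH]ccc5c4)c3)CC2)=C(c2ccc(C(F)(F)F)cc2)C1`: 24.2 nM
Compound 3 `CC1(C)CCC(CN2CCN(c3ccc(C(=O)NS(=O)(=O)c4ccc(NC5CCOC5)c([N+](=O)[O-])c4)c(Oc4cnc5[nH]ccc5c4)c3)CC2)=C(c2ccc(C(F)(F)F)cc2)C1`: 32 nM

All three values come from a functional assay on RS4-11 cells (Homo sapiens) for inhibition, read by CCK-8 assay, with a stated time of 72 h; a lower number here means a stronger inhibitor, a higher number a weaker inhibitor. Compound 3 cannot be told apart from its nearest neighbour, as the data show a 1.3-fold higher number from compound 2 to compound 3 (0.12 log units; within the scatter). The gap to the third compound is clearer, with an 8.2-fold higher number from compound 1 to compound 3 (0.91 log units; beyond the scatter).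

Compound 4 `CC1(C)CCC(CN2CCN(c3ccc(C(=O)NS(=O)(=O)c4ccc(OCC5CCOCC5)c([N+](=O)[O-])c4)c(Oc4cnc5[nH]ccc5c4)c3)CC2)=C(c2ccc(C(F)(F)F)cc2)C1` has not yet been measured. It carries (oxan-4-yl)methoxy in place of (oxolan-3-yl)amino on an aromatic carbon, ortho to a nitro group ((oxan-4-yl)methoxy in place of (oxolan-3-yl)amino on an aromatic carbon). Going by the values given here, no measured compound carries a group of this kind, so the data offer no direct guide. The closest evidence is the exchange between the two oxolane-bearing compounds, which gave only a 1.3-fold higher number from compound 2 to compound 3 (0.12 log units; within the scatter). The larger 6.2-fold higher number from compound 1 to compound 2 (0.79 log units; beyond the scatter) involved a 2-(dimethylamino)ethyl group, which compound 4 lacks.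

In this assay the expected step is a 1.3-fold higher number from compound 3 to compound 4 (0.10 log units; within the scatter), with no firm direction. For compound 4 the estimated value is 40 nM, within an expected range of 12 nM to 130 nM.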

Compound 4, half-maximal inhibitory concentration: 5.9 nM
Beside the measured number, compound 4's estimate is 6.8-fold (0.83 log units) above it, and the stated range ends above it.
By their numbers in this assay, from the lowest: compounds 1 and 4 (each within the scatter of the next); then compounds 2 and 3 (each within the scatter of the next).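

In this assay, replacing (oxolan-3-yl)amino with (oxan-4-yl)methoxy on the aromatic carbon ortho to a nitro group gave a 5.4-fold lower number from compound 3 to compound 4 (0.73 log units; beyond the scatter), and replacing ((oxolan-3-yl)methyl)amino gave a 4.1-fold lower number from compound 2 to compound 4 (0.61 log units; beyond the scatter), so this position can respond strongly to a neutral group, which the two oxolane compounds alone did not show. Compound 4 also has no dimethylamino group, yet a 1.5-fold higher number from compound 1 to compound 4 (0.18 log units; within the scatter) lies within the scatter, so among these compounds that group is not required to reach the range of compound 1. Nothing in the available data accounts for these steps.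

The compounds shown leave open whether the ether oxygen, the six-membered ring or the loss of the hydrogen-bond donor drives the shift, as these differences occur together. An (oxan-4-yl)methylamino group, which would keep the ring of compound 4 on an amino link, could help separate them.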